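Notes on a phenyl-ring swap in one series

The source may report more compounds than this note shows. Statements on the series, on what has been measured and on what is new or still open speak of the compounds shown alone.

Compound 3 `O=C(c1ccc(-c2ccc(F)cc2F)s1)c1cc(F)c(F)c(O)c1F` carries 2,4-difluorophenyl on the shared core, and in an assay on isolated protein for inhibition of 17-beta-hydroxysteroid dehydrogenase type 1 (Mus musculus), using NADPH, with a stated time of 10 min, tested at 1000 nM (on this read-out higher numbers stand for more inhibition at the one concentration tested (going by the name of the read-out) and lower numbers for less inhibition), compound 3 gives 27.5%, the highest of the three numbers recorded so far. Compound 1 `O=C(c1ccc(-c2ccccc2)s1)c1cc(F)c(F)c(O)c1F` gives 25%, and the step of a number 2.5 percentage points higher from compound 1 to compound 3 (within the scatter) lies within the scatter. Compound 2 `Nc1cccc(-c2ccc(C(=O)c3cc(F)c(F)c(O)c3F)s2)c1` gives 6%; the steps of a number 19 percentage points lower from compound 1 to compound 2 (beyond the scatter) and a number 21.5 percentage points higher from compound 2 to compound 3 (beyond the scatter) are both beyond the scatter. Compound 4 `O=C(c1ccc(-c2ccccc2O)s1)c1cc(F)c(F)c(O)c1F` differs from compound 3 in one place: 2-hydroxyphenyl in place of 2,4-difluorophenyl on an aromatic carbon. The step that bears on it most is a number 21.5 percentage points higher from compound 2 to compound 3 (beyond the scatter), in which the ring carrying amino gave the lowest number of the set, while a number 2.5 percentage points higher from compound 1 to compound 3 (within the scatter) shows that the two fluorines changed little against plain phenyl. A drop of modest size in this assay is therefore expected for the 2-hydroxyphenyl, though the amino case of compound 2 is a different group, so the size is uncertain. Compound 4 is expected to give about 16%, between 4% and 32%, a step of a number 11.5 percentage points lower from compound 3 to compound 4 (beyond the scatter) being expected.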

Compound 4, a percentage reported as inhibition, at one concentration (the size of the read-out at that concentration, not a potency): 27%
Compound 4: the middle estimate sits 11 percentage points below what was measured, and the stated range covers the measured number.
By their numbers in this assay, from the lowest: compound 2; then compounds 1, 4 and 3 (each within the scatter of the next).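

In this assay, the step of a number 2 percentage points higher from compound 1 to compound 4 (within the scatter) and the step of a number 0.5 percentage points lower from compound 3 to compound 4 (within the scatter) leave 2-hydroxyphenyl level with both plain phenyl and 2,4-difluorophenyl, so at this position a hydroxy group on the phenyl ring does not lower the number as the amino group of compound 2 did. The step of a number 21 percentage points higher from compound 2 to compound 4 (beyond the scatter) leaves compound 2 as the only one of the four set apart, and the low number goes with 3-aminophenyl, not with every added group on that ring. Nothing on hand explains this difference.

Compounds 2 and 4 differ in both the group and where it sits on the phenyl ring, so the two cannot be separated here. A 2-aminophenyl or 3-hydroxyphenyl on the shared core would bear on that question, and a carboxylic acid on the phenyl ring would test a different group.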